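Methylsulfanyl in place of trifluoromethoxy on the shared core

A few compounds are considered here, and "the series" means these few. Any claim that something is new, unique, unknown or untested is made for them only; others in the source may bear on it.

Measured compounds in a functional assay on HeLa cells (Homo sapiens) for antiproliferative activity, read by MTT assay, with a stated time of 72 h; a higher number here means a weaker inhibitor, a lower number a stronger inhibitor:
compound 1 `COc1cc(-n2ncnc2-c2ccc(OC(C)C)cc2)cc(OC)c1OC` gives 600 nM
compound 2 `CCOc1ccc(-c2ncnn2-c2cc(OC)c(OC)c(OC)c2)cc1` gives 15 nM
compound 3 `COc1cc(-n2ncnc2-c2ccc(OC(F)(F)F)cc2)cc(OC)c1OC` gives > 10000 nM

Compound 3 sits at a limit of this assay, not at a number (the limit of > 10000 nM in this assay, at which 1 of the 3 values shown sits). Within the data shown here, compound 2 and compound 1 are the only compounds with numbers, and both steps to compound 3 were large: an at least 16-fold higher number from compound 1 to compound 3 (1.22 log units; beyond the scatter), and an at least 660-fold higher number from compound 2 to compound 3 (2.82 log units; beyond the scatter). Between compound 1 and compound 2 the step is a 40-fold lower number from compound 1 to compound 2 (1.60 log units; beyond the scatter).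

Compound 4 `COc1cc(-n2ncnc2-c2ccc(SC)cc2)cc(OC)c1OC` differs from compound 3 in one place: methylsulfanyl in place of trifluoromethoxy on an aromatic carbon. The two measured steps that bear on it are those in which trifluoromethyl entered on the oxygen on an aromatic ring, each a large move toward a weaker inhibitor; the change to compound 4 removes trifluoromethoxy from that aromatic carbon, so the expected direction is the reverse, a lower number, well beyond the scatter. Among the measured compounds shown here, the size is uncertain since compound 3 is known only as a limit and methylsulfanyl has no measured analogue among the three compounds.

Compound 4 is estimated at 150 nM, within 20 nM to 3000 nM. That estimate means an expected step of an at least 66-fold lower number from compound 3 to compound 4 (1.82 log units; beyond the scatter).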

Compound 4, half-maximal inhibitory concentration: 150 nM
The estimate for compound 4 equals the measured number at the digits printed, within the range that was stated.
By their numbers in this assay, from the lowest: compound 2; then compound 4; then compound 1. At a limit, above all of these: compound 3.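

In this assay, compound 3 stands at a limit and not at a number: the limit of > 10000 nM in this assay, at which 1 of the 4 values shown sits.

Methylsulfanyl in place of trifluoromethoxy gives an at least 66-fold lower number from compound 3 to compound 4 (1.82 log units; beyond the scatter), so this aromatic carbon, para to a large group, can carry a group linked through sulfur and still give a measurable number, something the earlier compounds, all linked through oxygen, could not show. Set against the two oxygen-linked chains that gave numbers, methylsulfanyl falls between them, with a 10-fold higher number from compound 2 to compound 4 (1.00 log units; beyond the scatter) where it replaces ethoxy and a 4.0-fold lower number from compound 1 to compound 4 (0.60 log units; beyond the scatter) where it replaces isopropoxy, so an oxygen at this position is not required for a number in this range, although ethoxy still holds the lowest number of the four compounds.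

The compounds shown leave open whether ethylsulfanyl or isopropylsulfanyl would follow the order seen for ethoxy and isopropoxy, since methylsulfanyl is the only sulfur-linked group here. They also leave open how a dimethylamino group or a plain methoxy on this aromatic carbon would compare with methylsulfanyl, and whether the order of the compounds holds beyond this one cell line.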